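A few compounds are considered here, and "the series" means these few. Any claim that something is new, unique, unknown or untested is made for them only; others in the source may bear on it.

Among the compounds with values here, compound 2 `O=C(N[C@H](CO)C(=O)O)[C@@H]1C[C@H](O)CN1` is one of two compounds measured so far in a physicochemical assay for metabolic stability, read by HPLC, with a stated time of 12 h, at pH 1.2; on this read-out higher numbers stand for a longer-lived compound and lower numbers for a shorter-lived compound. In this assay compound 2 gives a value that is a limit of the assay, > 12 h. Compound 1 `O=C(N[C@H](CO)C(=O)O)[C@@H]1C[C@@H](O)CN1` has the same atoms and bonds as compound 2 and differs only in configuration as drawn. In this assay compound 1 also gives a value that is a limit, > 12 h. The step that the two limits leave unreadable from compound 1 to compound 2 therefore cannot be read as a number, because both values sit at the limit of > 12 h in this assay, at which 2 of the 2 values shown sit, and the pair differs only in configuration as drawn (the fact that compounds 1 and 2 differ only in the configuration as drawn).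

Compound 3 `O=C(O)[C@H](CO)NC(=O)[C@H]1C[C@H](O)CN1` has not yet been measured. It differs from compound 2 as follows: the two compounds have the same atoms and bonds and differ only in configuration as drawn: 2 of 3 stereo elements differ; a stereocentre at a saturated chain carbon is drawn R in compound 2 and S in compound 3; a stereocentre at a saturated ring carbon is drawn S in compound 2 and R in compound 3. Within the data shown here, the only measured step concerns a change of configuration and is itself unreadable, so no direction can be taken from it. With compound 1 and compound 2 both sitting at the limit (the limit of > 12 h in this assay, at which 2 of the 2 values shown sit), compound 3 is expected to sit there as well, the estimated step that the limit leaves unreadable from compound 2 to compound 3 staying within the scatter. Compound 3 is estimated at 15 h, with a range from 8 h to 40 h in this assay.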

Compound 3, half-life: > 12 h
Compound 3 gave a limit, no number; the forecaster's own chance of this, stated with the estimate: 80%; the middle value does not contradict the limit.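

Compound 3 joins compound 1 and compound 2 at the limit, so none of the steps among these three compounds can be read as a number: the limit of > 12 h in this assay, at which 3 of the 3 values shown sit.

The compounds shown leave open how long each of the three actually lasts in this assay, and whether the differences in configuration as drawn change that half-life at all.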